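Swapping the Thiocarbonyl Substituent of Compound 1

The compounds below may be only part of what the source reports. "The series", "measured", "known", "first", "only" and "open" are said of these compounds alone.

Compound 1 `Nc1ccccc1NC(=O)c1ccc(CSC(=S)N2CCc3ccccc32)cc1`: 3040 nM
Compound 2 `Nc1ccccc1NC(=O)c1ccc(CSC(=S)N2CCN(c3ccc(F)cc3)CC2)cc1`: > 32000 nM

Among the measured compounds shown here, in a functional assay on SMMC-7721 cells (Homo sapiens) for antiproliferative activity, read by CCK-8 assay, with a stated time of 72 h (on this read-out lower numbers stand for stronger inhibition and higher numbers for weaker inhibition), compound 1 gives 3040 nM, the only exact number available so far. Compound 2 reads > 32000 nM, which is a limit of the assay and not a number. Compound 1 therefore stands alone on the measured scale, with nothing yet to rank it against.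

Compound 3 `CC1CCCCN1C(=S)SCc1ccc(C(=O)Nc2ccccc2N)cc1` keeps the core of compound 1 and alters one group, with 2-methylpiperidin-1-yl in place of 2,3-dihydro-1H-indol-1-yl on a thiocarbonyl carbon. The change gives up the six-membered aromatic ring of carbon only. For the measured compounds named here, no measured step between related compounds is available to size this change. Even so, a modest move toward weaker inhibition is expected in this assay, slightly beyond the usual scatter and short of the limit seen for compound 2. The expected change is a 2.6-fold higher number from compound 1 to compound 3 (0.42 log units; beyond the scatter). The estimate for compound 3 is 8000 nM, with an expected range from 2000 nM to 30000 nM.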

Compound 3, half-maximal inhibitory concentration: 2950 nM
Compound 3: the middle estimate sits 2.7-fold (0.43 log units) above what was measured; low and high end bracket the measured number.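

In this assay, the exchange of 2,3-dihydro-1H-indol-1-yl for 2-methylpiperidin-1-yl on a thiocarbonyl carbon gives a 1.0-fold lower number from compound 1 to compound 3 (0.01 log units; within the scatter), so the two compounds cannot be told apart on this read-out. Among the compounds shown here, this is the first readable comparison at this position, and it shows that the six-membered aromatic ring of carbon only, present in the group that leaves and absent from the group that enters, is not required for a value of this size. Compound 2, which carries a different group at the same place, remains a limit of the assay and not a number: the limit of > 32000 nM in this assay, at which 1 of the 3 values shown sits.

The compounds shown leave open how a morpholin-4-yl group or an open-chain diethylamino group on the thiocarbonyl carbon would read, and whether either would stand with compound 1 and compound 3 or closer to the limit of compound 2. They also leave open what the methyl group of 2-methylpiperidin-1-yl contributes, a question that a plain piperidin-1-yl group on the same core would address directly.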